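The source may report more compounds than this note shows. Statements on the series, on what has been measured and on what is new or still open speak of the compounds shown alone.

Measured so far in a functional assay on cells (T-cell, Homo sapiens) for inhibition; a lower number here means a stronger inhibitor, a higher number a weaker inhibitor:
compound 1 `COc1ccc(-c2cnc3nc(N)nc(N4CCN(C(=O)c5ccccc5)CC4)c3n2)cc1OC` gives 400 nM;
compound 2 `COc1ccc(-c2cnc3nc(N)nc(N4CCN(C(=O)Nc5ccccc5)CC4)c3n2)cc1OC` gives 3.4 nM;
compound 3 `COc1ccc(-c2cnc3nc(N)nc(N4CCN(Cc5ccccc5)CC4)c3n2)cc1OC` gives 900 nM.

Compound 3 carries the highest number of the three; its nearest neighbour is compound 1 (a 2.3-fold higher number from compound 1 to compound 3 (0.35 log units; beyond the scatter)), while compound 2 lies far lower (a 260-fold higher number from compound 2 to compound 3 (2.42 log units; beyond the scatter)).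

Compound 4 `COc1ccc(-c2cnc3nc(N)nc(N4CCN(C(=O)CCc5ccccc5)CC4)c3n2)cc1OC` differs from compound 3 by phenethylcarbonyl in place of benzyl on an amine nitrogen in a ring. The step that bears most directly is compound 1 to compound 3, where a 2.3-fold higher number from compound 1 to compound 3 (0.35 log units; beyond the scatter) accompanied loss of the carbonyl; compound 4 restores a carbonyl, though with a phenethyl rather than phenyl group on it, and lacks the anilino that drove a 120-fold lower number from compound 1 to compound 2 (2.07 log units; beyond the scatter). A modest lowering of the number in this assay is therefore expected, about a 2.6-fold lower number from compound 3 to compound 4 (0.41 log units; beyond the scatter).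

Estimate for compound 4 in this assay: 350 nM, range 100 nM to 1200 nM.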

Compound 4, half-maximal inhibitory concentration: 100 nM
Estimate against measurement, compound 4: 3.5-fold (0.54 log units) above; measured number inside the range.
By their numbers in this assay, from the lowest: compound 2; then compound 4; then compound 1; then compound 3.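

In this assay, the group on the carbonyl carbon moves the number even without the anilino: phenethyl outdoes phenyl (a 4.0-fold lower number from compound 1 to compound 4 (0.60 log units; beyond the scatter)), and the step from benzyl is larger than the loss of carbonyl alone suggested (a 9.0-fold lower number from compound 3 to compound 4 (0.95 log units; beyond the scatter)). Phenethyl still falls well short of anilino (a 29-fold higher number from compound 2 to compound 4 (1.47 log units; beyond the scatter)). No evidence on the origin of these steps is available.

Open: whether a single methylene or a longer chain on the carbonyl carbon lies nearer compound 2 or compound 4, and whether a fluorine on the anilino ring keeps the low number of compound 2.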